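A few compounds are considered here, and "the series" means these few. Any claim that something is new, unique, unknown or untested is made for them only; others in the source may bear on it.

Among the compounds with values here, compound 1, with the structure `Cn1c(=O)cnn(CCCCN2CCN(c3ccccn3)CC2)c1=O`, is the one fully measured member of this small set. In an assay for displacement of a labelled ligand from Adrenergic receptor alpha-1 (Homo sapiens) (on this read-out higher numbers stand for weaker inhibition and lower numbers for stronger inhibition), compound 1 gives 262 nM. Compound 2, with the structure `Cn1c(=O)cnn(CCCCN2CCN(c3ncccc3F)CC2)c1=O`, differs from compound 1 by fluoro in place of hydrogen on an aromatic carbon. For compound 2 this assay reports only a limit, > 10000 nM. The step is an at least 38-fold higher number from compound 1 to compound 2 (1.58 log units; beyond the scatter).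

Compound 3 has the structure `Cn1c(=O)cnn(CCCN2CCN(c3ccccc3)CC2)c1=O`. How its core differs from the core of compound 1 is not broken down here. For compound 3 this assay again reports only a limit, > 10000 nM. Taken together, the values show (the limit of > 10000 nM in this assay, at which 2 of the 3 values shown sit).

Compound 4, with the structure `Cn1c(=O)cnn(CCCN2CCN(c3ccccc3F)CC2)c1=O`, has not been measured. It differs from compound 3 by fluoro in place of hydrogen on an aromatic carbon. Within the data shown here, this is the same kind of change as the one from compound 1 to compound 2, though the surroundings are not identical: in compound 2 the fluorine sits on a six-membered aromatic ring with one nitrogen, two atoms from the ring nitrogen, whereas in compound 4 it sits on a six-membered aromatic ring of carbon only.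

For compound 4 the expected step is a step that the limit leaves unreadable from compound 3 to compound 4, resting on compound 3 already giving > 10000 nM and on the direction of an at least 38-fold higher number from compound 1 to compound 2 (1.58 log units; beyond the scatter). Compound 4 is therefore estimated at 25000 nM, most likely to be reported again only as a limit, with a range from 8000 nM to 80000 nM.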

Compound 4, inhibition constant: > 10000 nM
Compound 4 gave a limit, no number; the forecaster's own chance of this, stated with the estimate: 85%; the middle value lies beyond the limit too.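

In this assay compound 4 gives > 10000 nM, which is a limit and not a number. Within the data shown here, compound 3 also stands at a limit, so no step from compound 3 to compound 4 can be read. The compounds shown leave open whether the change from phenyl to 2-fluorophenyl moves the value at all, since both compounds sit at the same limit: the limit of > 10000 nM in this assay, at which 3 of the 4 values shown sit.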